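This account rests on a few compounds, and the source may have more. Where it says the series, first, only, none or still open, it means among the compounds named here.

Working notes on the chalcone series.

Compound 1 `CN1CCN(C(=S)SCCCOc2ccc(C(=O)/C=C/c3ccc(Cl)cc3)cc2)CC1` was tested in a functional assay on MGC-803 cells (Homo sapiens) for inhibition, read by MTT assay, with a stated time of 72 h (on this read-out lower numbers stand for stronger inhibition and higher numbers for weaker inhibition), where compound 1 gives 29400 nM. Compound 2 `O=C(/C=C/c1cccs1)c1ccc(OCCSC(=S)N2CCCC2)cc1` was tested in this assay as well; there compound 2 gives 32400 nM. Compound 1 has the lowest of the two numbers, yet the two values sit within the scatter of each other, so no order between them can be read from the data.

The step now followed goes from compound 1 to compound 3 `COc1ccc(/C=C/C(=O)c2ccc(OCCCSC(=S)N3CCN(C)CC3)cc2)cc1`, not yet measured. The change is methoxy in place of chloro on an aromatic carbon. Within the data shown here, no measured pair with a comparable single change stands in the set, so the size of this step cannot be taken from a measured one. With nothing beyond the two close values of compound 1 and compound 2 to lean on, no step beyond the scatter is expected in this assay in either direction; the expected step is a 1.0-fold higher number from compound 1 to compound 3 (0.01 log units; within the scatter).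

Compound 3 is accordingly estimated to give 30000 nM, with a range from 12000 nM to 75000 nM.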

Compound 3, half-maximal inhibitory concentration: 19400 nM
Compound 3: the middle estimate sits 1.5-fold (0.19 log units) above what was measured; the range from low to high includes it.
By their numbers in this assay, from the lowest: compounds 3, 1 and 2 (each within the scatter of the next).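

Methoxy in place of chloro, para to a large group, is the first single-place step in the series: in this assay it gives a 1.5-fold lower number from compound 1 to compound 3 (0.18 log units; within the scatter) and so leaves the two groups indistinguishable on this read-out. This position therefore accepts 4-methoxyphenyl in place of 4-chlorophenyl without a step beyond the scatter, which compound 1 and compound 2 could not show, as they differ in more than one place. Nothing at hand offers an explanation for this result.

On these data alone, whether an amine or a carboxylic acid at this position would give a step beyond the scatter remains open. Also open, as far as these compounds go, is whether a longer chain on the ether oxygen would leave this methoxy for chloro step the same size.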